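The source may report more compounds than this note shows. Statements on the series, on what has been measured and on what is new or still open speak of the compounds shown alone.

Measured compounds:
compound 1, `O=C(CN(c1ncnc2c1ncn2C1CCCCO1)C1CC1)N[C@@H](CCC(=O)OCc1ccccc1)C(=O)OCc1ccccc1`, 34.7%
compound 2, `NC(=O)C[C@H](NC(=O)CN(c1nc(Cl)nc2[nH]cnc12)C1CC1)C(=O)O`, 43.1%
compound 3, `O=C(O)CNC(=O)CN(c1nc(Cl)nc2[nH]cnc12)C1CC1`, 38.9%

In a functional assay on the whole organism (Tail, strain ICR) with Mus musculus as the target, in the tail flick test, with a stated time of 60 min, at a dose of 25 umol/kg by the oral route (a lower number here means a weaker effect, a higher number a stronger effect of the compound at the dose given), compound 1 gives the lowest of the three numbers, yet the gap to compound 3 and the gap to compound 2 both lie within the scatter, so no order among the three can be read from them. Compound 4 is `C[C@H](NC(=O)CN(c1ncnc2c1ncn2C1CCCCO1)C1CC1)C(=O)OCc1ccccc1`; it differs from compound 1 as follows: hydrogen in place of (benzyloxycarbonyl)methyl on a saturated chain carbon, two bonds along the chain from an amide-type nitrogen and a carbonyl carbon. Going by the values given here, the only measured step of a related kind, the loss of a side chain from the same chain carbon, is a number 4.2 percentage points lower from compound 2 to compound 3 (within the scatter), which stayed within the scatter. On that basis compound 4 is expected to show no step beyond the scatter, with a number 0.3 percentage points higher from compound 1 to compound 4 (within the scatter) as the estimated change. Compound 4 is therefore estimated at 35%, with a range from 22% to 48%.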

Compound 4, a percentage reported as activity, at one dose (the size of the read-out at that dose, not a potency): 53%
The estimate for compound 4 lay 18 percentage points below the measured number, outside the stated range (above it).
By their numbers in this assay, from the lowest: compounds 1, 3, 2 and 4 (each within the scatter of the next, the first and the last beyond it).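

In this assay, the change from 2-(benzyloxycarbonyl)ethyl to methyl gives a number 18.3 percentage points higher from compound 1 to compound 4 (beyond the scatter), so on the core of compound 1 this side chain does affect the read-out. Going by these compounds alone, the related loss of carbamoylmethyl gave a number 4.2 percentage points lower from compound 2 to compound 3 (within the scatter), so the earlier compounds showed no such effect. Nothing available explains the step.
Still open, on these data alone, is whether an amine or a carboxylic acid at the end of that side chain would give a number nearer that of compound 1 or that of compound 4. As far as these compounds go, whether a longer chain in place of methyl would do the same also remains open.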